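A few compounds are considered here, and "the series" means these few. Any claim that something is new, unique, unknown or untested is made for them only; others in the source may bear on it.

Series notes. Compound 1 `CCOC(=O)c1nn(-c2ccc(Cl)cc2)c(-c2ccc(F)cc2)c1CNC(C)(C)C` is the reference point in a functional assay on PC-3 cells (Homo sapiens) for inhibition, read by sulforhodamine B assay, with a stated time of 48 h; on this read-out lower numbers stand for stronger inhibition of growth and higher numbers for weaker inhibition of growth. In this assay compound 1 gives 405000 nM; > 537000 nM (2 entries), and the several entries of compound 1 in this assay, 405000 nM; > 537000 nM (2 entries) gathers its several entries. Compound 2 `CC(C)(C)NCc1c(C(=O)O)nn(-c2ccc(Cl)cc2)c1-c1ccc(F)cc1` sits alongside it. In this assay compound 2 gives only a limit of the assay, > 623000 nM, and no number. Compound 2 thus stands without a numerical value in this assay, a further entry also lacking a single number. Compound 3 `COc1ccc(-c2c(CNC(C)(C)C)c(C(=O)O)nn2-c2ccc(Cl)cc2)cc1` is not yet measured. It differs from compound 2 by methoxy in place of fluoro on an aromatic carbon. Going by the values given here, no step between measured compounds is recorded, so the step expected for an at least 1.0-fold lower number from compound 2 to compound 3 (0.01 log units; that floor lies within the scatter) is taken as none beyond the usual scatter, with no direction implied. Compound 3 is accordingly estimated at 600000 nM, with a range from 250000 nM to 1500000 nM, most probably again reported only as a limit.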

Compound 3, concentration for 50% growth inhibition: > 605000 nM
Compound 3 gave a limit, no number; the forecaster's own chance of this, stated with the estimate: 70%; middle value at least 1.0-fold (0.00 log units) away from the limit.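

In this assay compound 2 and compound 3 both stand only as limits of the assay, not numbers, so no step can be read between them. The compounds shown leave open whether 4-fluorophenyl to 4-methoxyphenyl changes growth inhibition at all, in either direction.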